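A few compounds are considered here, and "the series" means these few. Any claim that something is new, unique, unknown or untested is made for them only; others in the source may bear on it.

Compound 1 `COC(=O)[C@H](CCSC)NC(=O)c1ccc(NCc2cncn2Cc2cccc(C#N)c2)cc1-c1ccccc1` was examined in a functional assay on NIH3T3 cells (Mus musculus); on this read-out lower numbers stand for an effect already at smaller amounts and higher numbers for an effect only at larger amounts of compound. In this assay compound 1 gives > 10 uM, which is a limit of the assay and not a number. Compound 2 `CSCC[C@H](NC(=O)c1ccc(NCc2cncn2Cc2cccc(Cl)c2)cc1-c1ccccc1)C(=O)O` was examined in the same way. In this assay compound 2 gives > 10 uM, again a limit of the assay rather than a measured number. Compound 1 thus stands at the limit, and the other value shown sits there too, as recorded by the limit of > 10 uM in this assay, at which 2 of the 2 values shown sit. Compound 3 `COC(=O)[C@H](CCSC)NC(=O)c1ccc(NCc2cncn2Cc2cccc([N+](=O)[O-])c2)cc1-c1ccccc1` has not yet been measured in this assay. It differs from compound 1 in one place: nitro in place of cyano on an aromatic carbon, meta to a large group, which cut one bond further out reads 3-cyanobenzyl to 3-nitrobenzyl. Within the data shown here, no step between measured compounds exists here. With compound 1 at a limit, the step is expected to be none beyond the scatter, and the change a step that the limit leaves unreadable from compound 1 to compound 3 is estimated accordingly. Compound 3 is expected to give about 20 uM in this assay, within a range from 5 uM to 80 uM, most likely again reported only as a limit.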

Compound 3, concentration for half-maximal effect: > 10 uM
Compound 3: only a limit was reported; the forecaster's own chance of this, stated with the estimate: 75%; the middle value does not contradict the limit.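

Compound 1 and compound 3 both remain at a limit of the assay rather than a number, so the change from cyano to nitro cannot be read in this assay: the limit of > 10 uM in this assay, at which 3 of the 3 values shown sit.

The compounds shown leave open how far any of them lies from that limit, and whether this change alters the effect at all.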